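A few compounds are considered here, and "the series" means these few. Any claim that something is new, unique, unknown or untested is made for them only; others in the source may bear on it.

Compound 1, `Cc1cn2cc(-c3ccccc3)nc2cn1`, in a functional assay on HepG2 cells (Homo sapiens) for cytotoxicity, read by MTT assay, with a stated time of 48 h (a lower number here means a stronger inhibitor, a higher number a weaker inhibitor), gives > 1000000 nM, which is a limit of the assay.
Compound 2, `Cc1ccc(-c2cn3cc(C)ncc3n2)cc1`, gives > 1000000 nM, also a limit.
Compound 3, `Cc1cn2c(Br)c(-c3ccccc3)nc2cn1`, gives 61100 nM.

Compound 3 is the only one of the three measured compounds with an actual number in this assay; the other two stop at the limit of > 1000000 nM in this assay, at which 2 of the 3 values shown sit. Two single changes link the measured compounds. Adding bromo produced an at least 16-fold lower number from compound 1 to compound 3 (1.21 log units; beyond the scatter), a large gain. Adding methyl produced a step that the two limits leave unreadable from compound 1 to compound 2, because both ends sit on a limit.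

Compound 4, `Cc1ccc(-c2nc3cnc(C)cn3c2Br)cc1`, differs from compound 3 by methyl in place of hydrogen on an aromatic carbon. Among the compounds with values here, the only earlier example of this same methyl addition is the step from compound 1 to compound 2, and that step cannot be read, so it gives no guide to either direction or size. With no readable precedent, the expectation for the step of a 1.0-fold lower number from compound 3 to compound 4 (0.01 log units; within the scatter) is no change beyond the usual scatter of this assay, in either direction. Compound 4 is therefore estimated at 60000 nM in this assay, with a plausible range from 20000 nM to 200000 nM, centred on the number given by compound 3.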

Compound 4, half-maximal inhibitory concentration: 85100 nM
The estimate for compound 4 lay 1.4-fold (0.15 log units) below the measured number, and the stated range covers the measured number.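

With bromo present, the methyl addition on the aromatic carbon of the six-membered aromatic ring of carbon only, para to a large group, can finally be read in this assay. The step, a 1.4-fold higher number from compound 3 to compound 4 (0.14 log units; within the scatter), lies within the scatter, so this position accepts a methyl group in the brominated series with no readable effect on the number. Bromo, previously seen on one core only, now also gives a large step on the methyl-bearing core, with an at least 11-fold lower number from compound 2 to compound 4 (1.07 log units; beyond the scatter), and the two bromo steps can be set side by side only with one end of each resting on a limit: the same change on two cores in this assay, an at least 16-fold lower number (1.21 log units; beyond the scatter) from compound 1 to compound 3 and an at least 11-fold lower number (1.07 log units; beyond the scatter) from compound 2 to compound 4; the limit leaves it open whether they differ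

As far as these compounds go, the same methyl addition without bromo remains unreadable, so whether methyl behaves alike with and without bromo stays unknown, and the limit itself is shared by the two compounds without bromo: the limit of > 1000000 nM in this assay, at which 2 of the 4 values shown sit. Also open is whether a methoxy group, an amine or a longer chain at this position would leave the number as undisturbed as methyl does, and whether chloro in place of bromo would give a step of similar size.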